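The source may report more compounds than this note shows. Statements on the series, on what has been measured and on what is new or still open speak of the compounds shown alone.

Compound 1 `CCC(CC)O[C@@H]1C=C(C(=O)Nc2ccccc2)C[C@H](N)[C@H]1NC(C)=O`: 375000 nM
Compound 2 `CCC(CC)O[C@@H]1C=C(C(=O)O)C[C@H](NC(=O)OC(C)(C)C)[C@H]1NC(C)=O`: 750000 nM

Both values come from an ADME assay on HeLa cells (Homo sapiens) for cytotoxicity, with a stated time of 24 h; a lower number here means that less compound is tolerated, a higher number that more compound is tolerated. There, compound 2 at 750000 nM lies within the usual scatter of compound 1 at 375000 nM, so the two stand level on these numbers.

Compound 3 `CCC(CC)O[C@@H]1C=C(C(=O)Nc2ccccc2OC)C[C@H](NC(=O)OC(C)(C)C)[C@H]1NC(C)=O` differs from compound 2 in one place: (2-methoxyphenyl)amino in place of hydroxy on a carbonyl carbon, with (2-methoxyphenyl)amino in place of hydroxy on a carbonyl carbon. For the measured compounds named here, no two measured compounds differ in only one place, so the effect of this change has not been measured directly. The nearest guide is compound 1, which also carries an aromatic amide on that carbonyl and gives 375000 nM. A small downward step in this assay is therefore expected, hardly beyond the scatter. The expected change is a 1.9-fold lower number from compound 2 to compound 3 (0.27 log units; within the scatter). For compound 3 the estimated value is 400000 nM, with an expected range from 130000 nM to 900000 nM.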

Compound 3, half-maximal cytotoxic concentration: > 1000000 nM
Compound 3 was reported as a limit (the forecaster's own chance of this, stated with the estimate: 25%); middle value at least 2.5-fold (0.39 log units) from the limit.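

In this assay compound 3 gives > 1000000 nM, which is a limit of the assay and not a number. Placing (2-methoxyphenyl)amino instead of hydroxy on this carbonyl carbon gives an at least 1.3-fold higher number from compound 2 to compound 3 (0.12 log units; that floor lies within the scatter), so this is the first direct reading of a change at this position, and it shows no lower number with the aromatic amide in place. The true size of the step cannot be read, and its floor alone does not establish a real rise: the limit of > 1000000 nM in this assay, at which 1 of the 3 values shown sits.

Going by these compounds, it remains open how a plain phenylamino group or a simple alkylamine on this carbonyl carbon would read with the rest of compound 3 kept. On these data alone, compound 1 differs from compound 3 in more than one place, so the separate contributions of the methoxy group and the free amine also remain open.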